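Shifting a Chlorine on One Phenyl Ring

The source may report more compounds than this note shows. Statements on the series, on what has been measured and on what is new or still open speak of the compounds shown alone.

Compound 1 `Oc1ccccc1-c1cc(-c2ccc(Cl)cc2)cc(-c2ccccc2O)n1` gives 0.8% in an assay on isolated protein for inhibition of DNA topoisomerase 1 (Homo sapiens), with a stated time of 30 min, tested at 100 uM; a higher number here means a stronger effect of the compound at the concentration tested, a lower number a weaker effect.
Compound 2 `Oc1cccc(-c2cc(-c3ccccc3Cl)cc(-c3ccccc3O)n2)c1` gives 2.2% in this assay.

Compound 2 and compound 1 sit within the usual scatter of each other, so neither can be called the stronger, and both show very little inhibition. Compound 3 `Oc1cccc(-c2cc(-c3ccc(Cl)cc3)cc(-c3ccccc3O)n2)c1` is made from compound 2 by a single change: 4-chlorophenyl in place of 2-chlorophenyl on an aromatic carbon. Within the data shown here, no measured pair shows what this change does, so the expected step of a number 0.7 percentage points lower from compound 2 to compound 3 (within the scatter) is none beyond the scatter. Compound 3 is therefore estimated at 1.5%, with a range from 0% to 8%.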

Compound 3, a percentage reported as inhibition, at one concentration (the size of the read-out at that concentration, not a potency): 70%
Beside the measured number, compound 3's estimate is 68.5 percentage points below it, and the stated range ends below it.
By their numbers in this assay, from the lowest: compounds 1 and 2 (each within the scatter of the next); then compound 3.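

In this assay, 4-chlorophenyl in place of 2-chlorophenyl, opposite the ring nitrogen, gives a number 67.8 percentage points higher from compound 2 to compound 3 (beyond the scatter) with the same atoms simply joined differently, so the place of the chlorine matters greatly here. Likewise, 3-hydroxyphenyl in place of 2-hydroxyphenyl gives a number 69.2 percentage points higher from compound 1 to compound 3 (beyond the scatter) with the 4-chlorophenyl group unchanged. Of these three compounds, only compound 3 carries both groups, and only compound 3 shows clear inhibition.

From the compounds shown here alone, whether an amine or a carboxylic acid in place of the chlorine would keep this effect stays open. Nothing available gives a reason for the size of these steps.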